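The source may report more compounds than this note shows. Statements on the series, on what has been measured and on what is new or still open speak of the compounds shown alone.

Of the compounds shown here, two so far carry a number in a functional assay on A549 cells (Homo sapiens) for antiproliferative activity, read by MTT assay, with a stated time of 24 h; on this read-out higher numbers stand for weaker inhibition and lower numbers for stronger inhibition. Compound 1 `COc1ccc(C(=O)/C=C/c2cc(-c3cc(OC)c(OC)c(OC)c3)n3nc(-c4ccccc4)cc3n2)cc1` gives 14600 nM in this assay. Compound 2 `COc1ccc(C(=O)/C=C/c2cc(-c3ccc(OC)c(OC)c3)n3nc(-c4ccccc4)cc3n2)cc1` gives 11900 nM in this assay, which is the lowest of the two numbers, with compound 1 the nearest, although the gap between them is within the scatter. Among the compounds with values here, the only step with a number behind it, a 1.2-fold lower number from compound 1 to compound 2 (0.09 log units; within the scatter), is hydrogen in place of methoxy on an aromatic carbon, and it left the number essentially where it was.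

Compound 3 `COc1ccc(C(=O)/C=C/c2cc(-c3ccc(OC)cc3)n3nc(-c4ccccc4)cc3n2)cc1` has not yet been measured. It differs from compound 2 by hydrogen in place of methoxy on an aromatic carbon. Within the data shown here, this is the same kind of change as the one measured step, and that step stayed within the scatter. No step beyond the scatter is therefore expected in this assay, the change being a 1.0-fold higher number from compound 2 to compound 3 (0.00 log units; within the scatter) as estimated. For compound 3 the estimate in this assay is 12000 nM, with a range from 5000 nM to 30000 nM. A single measured step is thin ground for this expectation, and the range is set wide accordingly.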

Compound 3, half-maximal inhibitory concentration: 2900 nM
The estimate for compound 3 lay 4.1-fold (0.62 log units) above the measured number; the whole stated range lies above it.
By their numbers in this assay, from the lowest: compound 3; then compounds 2 and 1 (each within the scatter of the next).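

In this assay, going from 3,4-dimethoxyphenyl to 4-methoxyphenyl gives a 4.1-fold lower number from compound 2 to compound 3 (0.61 log units; beyond the scatter) and so moves the number beyond the scatter, whereas the same kind of change in a 1.2-fold lower number from compound 1 to compound 2 (0.09 log units; within the scatter) did not. Hydrogen in place of methoxy on this ring therefore has no single size of effect in these compounds: the outcome differs with the methoxy that leaves and the groups that stay, and compound 1 to compound 2 stands against any general rule that removing a methoxy lowers the number. The full change from 3,4,5-trimethoxyphenyl to 4-methoxyphenyl amounts to a 5.0-fold lower number from compound 1 to compound 3 (0.70 log units; beyond the scatter) and leaves compound 3 with the lowest number of the three, though nothing at hand bears on why the two methoxy removals differ.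

The compounds shown leave open whether the remaining methoxy of the 4-methoxyphenyl group contributes at all, a question that a plain phenyl or a hydroxyl, an amine or a chlorine in its place would address. From the compounds shown here alone, it also remains open whether the same ring change would give a similar step with a different group in place of the phenyl on the shared core.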